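The source may report more compounds than this note shows. Statements on the series, on what has been measured and on what is new or still open speak of the compounds shown alone.

Compound 1 `Cc1c(C(c2ccccc2)c2cc3ccccc3o2)[nH]c2ccccc12` was examined in a functional assay on SiHa cells (Homo sapiens) for cytotoxicity; on this read-out higher numbers stand for weaker inhibition and lower numbers for stronger inhibition. In that assay compound 1 gives only a limit of the assay, > 100000 nM. Two relatives share its core. Compound 2 `Cc1c(C(c2ccccc2)c2cc3cc(Cl)ccc3o2)[nH]c2ccccc12` differs from compound 1 by chloro in place of hydrogen on an aromatic carbon, and in this assay compound 2 gives 77900 nM. Compound 3 `COc1ccc2oc(C(c3ccccc3)c3[nH]c4ccccc4c3C)cc2c1` differs from compound 1 by methoxy in place of hydrogen on an aromatic carbon. In this assay compound 3 gives only a limit of the assay, > 100000 nM. Two of the three values thus sit at the limit of > 100000 nM in this assay, at which 2 of the 3 values shown sit. The measured steps are an at least 1.2-fold lower number from compound 1 to compound 2 (0.10 log units; that floor lies within the scatter), a step that the two limits leave unreadable from compound 1 to compound 3 and an at least 1.2-fold higher number from compound 2 to compound 3 (0.10 log units; that floor lies within the scatter). Compound 4 `Cc1c(C(c2ccc(Cl)cc2)c2cc3ccccc3o2)[nH]c2ccccc12` differs from compound 1 by chloro in place of hydrogen on an aromatic carbon, the chlorine sitting para to a large group. For the measured compounds named here, the only comparable change, the step of an at least 1.2-fold lower number from compound 1 to compound 2 (0.10 log units; that floor lies within the scatter), did not leave the scatter. The step of an at least 1.2-fold lower number from compound 1 to compound 4 (0.09 log units; that floor lies within the scatter) is therefore expected to stay within the scatter as well. Compound 4 is estimated at 80000 nM, with a range from 30000 nM to 200000 nM, in this assay.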

Compound 4, half-maximal inhibitory concentration: 72500 nM
Compound 4: middle estimate off by 1.1-fold (0.04 log units), on the high side; measured number inside the range.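

In this assay, the change from phenyl to 4-chlorophenyl shows that the phenyl ring is a second place where chloro goes with a measured number rather than a limit, as it does at its different place in compound 2. The step reads an at least 1.3-fold lower number from compound 1 to compound 4 (0.13 log units; that floor lies within the scatter), so the floor of this change, like that of the earlier chloro change, shows nothing beyond the scatter. How large the step really is stays unreadable because compound 1 is only a limit of the assay: the limit of > 100000 nM in this assay, at which 2 of the 4 values shown sit.

The compounds shown leave open whether a methoxy, an amine or a carboxylic acid in place of this chloro would also give a measured number. They also leave open whether any change on the phenyl ring can move the number clearly beyond the scatter.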